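A few compounds are considered here, and "the series" means these few. Any claim that something is new, unique, unknown or untested is made for them only; others in the source may bear on it.

Measured compounds:
compound 1, `O=C(O)c1cc2c(Nc3ccc(OC(F)(F)F)cc3)ncnc2s1`: > 10000 nM
compound 2, `CCCn1ncc2c(Nc3ccc(OC(F)(F)F)cc3)ncnc21`: 6600 nM

Both compounds share a common core and the same substituted aniline part, and both were tested in an ADME assay on BaF3 cells (Mus musculus) for cytotoxicity; on this read-out lower numbers stand for an effect already at smaller amounts and higher numbers for an effect only at larger amounts of compound. In this assay, for the measured compounds named here, compound 2 gives 6600 nM, which is the only plain number in the set. For compound 1 the reported value > 10000 nM is a limit of the assay, not a number (the limit of > 10000 nM in this assay, at which 1 of the 2 values shown sits). Going by the values given here, compound 2 therefore stands alone as the one compound with a measured amount, with compound 1 giving only a limit.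

Compound 3, `FC(F)(F)Oc1ccc(Nc2ncnc3c2cnn3Cc2ccccc2)cc1`, has not yet been measured. It differs from compound 2 in one place: phenyl in place of ethyl on a saturated chain carbon bound to an aromatic nitrogen. Among the compounds with values here, no measured pair differs in a similar way, so the size of such a step is not known from the numbers at hand. The expectation is a step from compound 2 to compound 3 of a 1.3-fold lower number from compound 2 to compound 3 (0.12 log units; within the scatter) in this assay, no larger than the usual scatter. Compound 3 is therefore estimated at 5000 nM, with a range from 1800 nM to 14000 nM.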

Compound 3, half-maximal effective concentration: > 10000 nM
Compound 3: only a limit was reported (the forecaster's own chance of this, stated with the estimate: 25%); middle value at least 2.0-fold (0.30 log units) away from the limit.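

In this assay compound 3 gives > 10000 nM, which is a limit of the assay and not a number. Replacing propyl with benzyl, which puts a six-membered aromatic ring on this saturated chain carbon, gives an at least 1.5-fold higher number from compound 2 to compound 3 (0.18 log units; that floor lies within the scatter), so this larger group did not move the effect to smaller amounts of compound, although the floor of the step is no larger than the usual scatter. The true size of the step cannot be read because the result stops at the top of the range: the limit of > 10000 nM in this assay, at which 2 of the 3 values shown sit.

For the compounds shown here, open is whether any group in this place would move the number downwards, since only one direction of change is seen here. An amine or a longer chain on this carbon could answer that, and a plain number for such a compound would show how much this place matters.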